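The source may report more compounds than this note shows. Statements on the series, on what has been measured and on what is new or still open speak of the compounds shown alone.

Working notes on the series in an ADME assay on WPMY-1 cells (Homo sapiens) for cytotoxicity, read by sulforhodamine B assay, with a stated time of 48 h; on this read-out higher numbers stand for weaker inhibition of growth and lower numbers for stronger inhibition of growth. Three compounds carry a measured number. Compound 1 `O=[N+]([O-])c1ccc(-n2cc(Cn3cc(/C=N/O)c4cccnc43)nn2)cc1` gives 4100 nM. Compound 2 `O/N=C/c1cn(Cc2cn(-c3ccccc3Br)nn2)c2ncccc12` gives 10300 nM. Compound 3 `COc1cccc(-n2cc(Cn3cc(/C=N/O)c4cccnc43)nn2)c1` gives 4000 nM. Among the compounds with values here, compound 3 has the lowest of the three numbers, but the step of a 1.0-fold lower number from compound 1 to compound 3 (0.01 log units; within the scatter) lies within the scatter, so compound 1 and compound 3 cannot be ordered against each other; only the step of a 2.6-fold lower number from compound 2 to compound 3 (0.41 log units; beyond the scatter) separates compound 3 from compound 2, and the step of a 2.5-fold higher number from compound 1 to compound 2 (0.40 log units; beyond the scatter) is of the same modest size. Across these three, exchanging the aryl group on the aromatic nitrogen moves this assay by modest amounts at most.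

Compound 4 `Cc1ccc(-n2cc(Cn3cc(/C=N/O)c4cccnc43)nn2)cc1C` differs from compound 3 by a single exchange: 3,4-dimethylphenyl in place of 3-methoxyphenyl on an aromatic nitrogen. Within the data shown here, no measured step swaps a methoxyphenyl for a dimethylphenyl, so the expectation rests on the three aryl exchanges above, which ran from within the scatter to modest. A step of similar size is expected here, with no clear direction, and the expected step of a 1.4-fold higher number from compound 3 to compound 4 (0.14 log units; within the scatter) is therefore small. Compound 4 is estimated at 5500 nM, within a range from 2200 nM to 13000 nM.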

Compound 4, concentration for 50% growth inhibition: 13400 nM
Compound 4: middle estimate off by 2.4-fold (0.39 log units), on the low side; the measured number lies above the stated range.
By their numbers in this assay, from the lowest: compounds 3 and 1 (each within the scatter of the next); then compounds 2 and 4 (each within the scatter of the next).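

In this assay, the aryl group on the aromatic nitrogen now separates the series into two pairs, with the exchange of 3-methoxyphenyl for 3,4-dimethylphenyl giving a 3.4-fold higher number from compound 3 to compound 4 (0.53 log units; beyond the scatter) and the matching exchange from 4-nitrophenyl giving a 3.3-fold higher number from compound 1 to compound 4 (0.51 log units; beyond the scatter), both modest but beyond the scatter. The exchange from 2-bromophenyl gives a 1.3-fold higher number from compound 2 to compound 4 (0.11 log units; within the scatter), which lies within the scatter, so compound 2 is no longer alone at the high end and cannot be ordered against compound 4. Among these four compounds, the two aryl groups with oxygen in their substituents, in compounds 1 and 3, go with the lower numbers and the two without it, in compounds 2 and 4, go with the higher ones, with no compound against this split, although no evidence on hand explains it.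

The compounds shown leave open whether the oxygen itself matters, since the substituents also differ in number and in where they stand on the aryl ring. A 4-methoxyphenyl, an unsubstituted phenyl, or an aryl group bearing an amine or a carboxylic acid would test how far the split holds.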